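Methyl Additions and Cytotoxicity in Fibroblasts

A few compounds are considered here, and "the series" means these few. Any claim that something is new, unique, unknown or untested is made for them only; others in the source may bear on it.

Measured so far:
compound 1 `C/C(=C\c1cc(-c2ccccc2)cs1)C(N)=O`: > 50000 nM
compound 2 `C/C(=C\c1cccc(-c2ccccc2)c1)C(N)=O`: > 50000 nM
compound 3 `C/C(=C\c1cccc(-c2ccc(C)cc2)c1)C(N)=O`: > 50000 nM

In an ADME assay on NIH3T3 cells (Mus musculus) for cytotoxicity, read by CCK-8 assay, with a stated time of 24 h (on this read-out higher numbers stand for weaker inhibition and lower numbers for stronger inhibition), compound 1 gives > 50000 nM, which is a limit of the assay and not a number. Compound 2 likewise gives > 50000 nM, a limit. Compound 3 gives > 50000 nM, again a limit. The change from compound 2 to compound 3 is methyl in place of hydrogen on an aromatic carbon, and its step that the two limits leave unreadable from compound 2 to compound 3 stays unreadable because of the limit of > 50000 nM in this assay, at which 3 of the 3 values shown sit. The difference between the core of compound 1 and the core of compound 2 is not broken down here.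

Compound 4 `C/C(=C\c1cc(-c2ccccc2C)cs1)C(N)=O` differs from compound 1 by methyl in place of hydrogen on an aromatic carbon. This is the same kind of change as that from compound 2 to compound 3, but the place differs: ortho to a large group rather than para to a large group. Since every value shown sits at the limit, compound 4 is expected to remain at the limit as well, giving an estimated step that the limit leaves unreadable from compound 1 to compound 4. The estimate for compound 4 is 60000 nM, within 30000 nM to 200000 nM.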

Compound 4, half-maximal inhibitory concentration: > 50000 nM
Compound 4 ended at the assay's limit; the forecaster's own chance of this, stated with the estimate: 85%; the middle value lies beyond the limit too.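

No new step can be read between compound 1 and compound 4, as both values are limits: the limit of > 50000 nM in this assay, at which 4 of the 4 values shown sit. The compounds shown leave open whether methyl in place of hydrogen on an aromatic carbon changes cytotoxicity at all.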